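This account rests on a few compounds, and the source may have more. Where it says the series, first, only, none or still open, it means among the compounds named here.

Compound 1 `CNc1nc(N)c2sc(-c3ccc(C(F)(F)F)cc3)cc2n1` is the least soluble of the two compounds measured: in a physicochemical assay for solubility, in phosphate buffer, at pH 6.5 (a higher number here means a more soluble compound, a lower number a less soluble compound), compound 1 gives 3.1 ug/mL, while compound 2 `CNc1nc(N2CCC(N)CC2)c2sc(-c3ccc(C(F)(F)F)cc3)cc2n1` gives 17 ug/mL, a step of a 5.5-fold higher number from compound 1 to compound 2 (0.74 log units; beyond the scatter). Compound 3 `CNc1nc(Nc2cccc(S(C)(=O)=O)c2)c2sc(-c3ccc(C(F)(F)F)cc3)cc2n1` differs from compound 1 by 3-(methylsulfonyl)phenyl in place of hydrogen on a nitrogen on an aromatic ring. Among the compounds with values here, no measured step replaces a hydrogen on that nitrogen with an aromatic group, so the single step in this assay offers only weak guidance. The added group brings no charge, so a small fall or no change beyond the scatter is expected, a 2.1-fold lower number from compound 1 to compound 3 (0.32 log units; beyond the scatter), giving an estimated 1.5 ug/mL for compound 3, within 0.4 ug/mL to 6 ug/mL.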

Compound 3, solubility: < 5 ug/mL
Compound 3 gave a limit, no number (the forecaster's own chance of this, stated with the estimate: 10%); the middle value does not contradict the limit.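

Compound 3 gives < 5 ug/mL in this assay, which is a limit and not a number, so the step from compound 1 to compound 3 cannot be read. On these data alone, whether compound 3 is more or less soluble than compound 1 stays open.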